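This account rests on a few compounds, and the source may have more. Where it says the series, first, only, none or still open, it means among the compounds named here.

Working notes on the series in an assay on isolated protein for inhibition of Rho-associated protein kinase 2 (Homo sapiens), read by scintillation counting, radiometric assay and 33P incorporation, with a stated time of 40 min, in the presence of a further agent that is not named here; a lower number here means a stronger inhibitor, a higher number a weaker inhibitor.

Two compounds have numbers. Compound 1 `O=C(COc1ccc2c(=O)ccoc2c1)Nc1cccc(NC(=O)c2ccc(F)cc2)c1` gives 54 nM in this assay. Compound 2 `COc1ccc(C(=O)Nc2cccc(NC(=O)COc3ccc4c(=O)ccoc4c3)c2)cc1` gives 7 nM. Going by the values given here, the one measured step between them, methoxy in place of fluoro on an aromatic carbon, reads a 7.7-fold lower number from compound 1 to compound 2 (0.89 log units; beyond the scatter), so compound 2 holds the lowest of the two numbers, with compound 1 as its nearest neighbour at a gap beyond the scatter.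

Compound 3 `O=C(COc1ccc2c(=O)ccoc2c1)Nc1cccc(NC(=O)c2ccc(OC(F)(F)F)cc2)c1` is not yet measured. It differs from compound 2 by trifluoromethyl in place of methyl on an oxygen on an aromatic ring. Among the compounds with values here, no measured step shows this change; the only step known is the one from compound 1 to compound 2, which exchanges the whole group on that aromatic carbon rather than the carbon on the oxygen. That step is modest and says the group at this position can move the number, but gives no direction for a trifluoromethyl on the oxygen. The expectation for compound 3 is therefore a step of a 2.9-fold higher number from compound 2 to compound 3 (0.46 log units; beyond the scatter), in the direction of a weaker inhibitor, with wide uncertainty. Compound 3 is estimated at 20 nM, with a range from 5 nM to 80 nM.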

Compound 3, half-maximal inhibitory concentration: 77 nM
The estimate for compound 3 lay 3.9-fold (0.59 log units) below the measured number; the range from low to high includes it.
By their numbers in this assay, from the lowest: compound 2; then compounds 1 and 3 (each within the scatter of the next).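

Within this assay, the change from methoxy to trifluoromethoxy keeps the oxygen on the aromatic ring and alters only the group on it, yet it gives an 11-fold higher number from compound 2 to compound 3 (1.04 log units; beyond the scatter), a large step that is larger than the one between fluoro and methoxy. Trifluoromethoxy in place of fluoro on the aromatic carbon gives a 1.4-fold higher number from compound 1 to compound 3 (0.15 log units; within the scatter), so these two groups cannot be told apart in this assay and, among the three groups shown, only methoxy gives the lower number. The series therefore shows that an oxygen on the ring is not enough on its own for the lower number, and that the group carried by that oxygen has a strong bearing on the result, while nothing presented accounts for the size of this step.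

The compounds shown leave open whether the low number of compound 2, 7 nM, is particular to a methyl on the oxygen or also holds for a longer chain such as ethyl, or for a hydroxyl group. As far as these compounds go, it also remains open how an amine such as dimethylamino would read on the same aromatic carbon.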